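Stripping the Thiazolylmethyl Group from Compound 2

A few compounds are considered here, and "the series" means these few. Any claim that something is new, unique, unknown or untested is made for them only; others in the source may bear on it.

Of the compounds shown here, three have been tested in a functional assay (blood) for inhibition, with Homo sapiens as the target; on this read-out lower numbers stand for stronger inhibition and higher numbers for weaker inhibition. Compound 1 `OC1O[C@H](CO/N=C2\CCc3cc(Sc4cc(F)cc(C5CCOCC5)c4)ccc32)[C@H](O)[C@H](O)[C@H]1O` reaches only the limit of the assay, > 2500 nM. Compound 2 `CCOC(=O)c1csc(CO/N=C(\C)c2ccc(Sc3cc(F)cc(C4CCOCC4)c3)cc2)n1` gives 150 nM, the higher of the two actual numbers, while compound 3 `COC1(c2cc(F)cc(Sc3ccc4c(c3)OCC/C4=N\OCC#N)c2)CCOCC1` gives 40 nM, a gap that lies beyond the scatter. Compound 4 `C/C(=N\O)c1ccc(Sc2cc(F)cc(C3CCOCC3)c2)cc1` has not yet been measured; it differs from compound 2 by hydrogen in place of (4-(ethoxycarbonyl)-1,3-thiazol-2-yl)methyl on an oxygen. Going by the values given here, no measured pair shows this change, and the size of the step is therefore uncertain. The account expects the removal of the (4-(ethoxycarbonyl)-1,3-thiazol-2-yl)methyl group to weaken inhibition by a step beyond the scatter, a 4.0-fold higher number from compound 2 to compound 4 (0.60 log units; beyond the scatter). Compound 4 is accordingly estimated at 600 nM, with a likely range from 150 nM to 2500 nM.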

Compound 4, half-maximal inhibitory concentration: 80 nM
Compound 4: middle estimate off by 7.5-fold (0.88 log units), on the high side; the whole stated range lies above it.
By their numbers in this assay, from the lowest: compounds 3, 4 and 2 (each within the scatter of the next, the first and the last beyond it). At a limit, above all of these: compound 1.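

In this assay, removing the (4-(ethoxycarbonyl)-1,3-thiazol-2-yl)methyl group gives a 1.9-fold lower number from compound 2 to compound 4 (0.27 log units; within the scatter), so this group of 11 heavy atoms is not needed for inhibition at the level seen here. On the oxygen, hydrogen and this much larger group cannot be told apart by this read-out. Nothing measured here gives a reason for this result.

As far as these compounds go, whether a methyl group or a longer chain ending in a carboxylic acid on that oxygen would hold inhibition remains open. Compound 1 and compound 3 differ from compound 4 in more than one place, so they do not settle it.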